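This account rests on a few compounds, and the source may have more. Where it says the series, first, only, none or still open, it means among the compounds named here.

Notes on the series. Compound 1 `CCOC(=O)C1CCCC(c2ccc(OCC)cc2)N1` in an assay on COS-7 cells for inhibition of patatin-like phospholipase domain-containing protein 2 (Mus musculus) (a higher number here means a weaker inhibitor, a lower number a stronger inhibitor), gives only a limit, > 200000 nM, and no number. Compound 2 `CCOc1ccc(-c2cccc(C)c2)cc1` in this assay gives 70000 nM. Compound 3 `CN(C)c1ccc(-c2cccc(N)c2)cc1` in this assay gives 100000 nM; of the two numbers this is the higher one, but its separation from compound 2 lies within the scatter, so the two are not distinguished from each other. For compound 1 what stands is the limit of > 200000 nM in this assay, at which 1 of the 3 values shown sits. Going by the values given here, no step between measured compounds that differ in a single place is available, so no measured change can be drawn on directly.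

Compound 4 `CC(C)COC(=O)Nc1cccc(-c2ccc(N(C)C)cc2)c1` differs from compound 3 by isobutoxycarbonyl in place of hydrogen on a nitrogen on an aromatic ring. Compared with compound 3, compound 4 is expected to give a lower number in this assay, a step beyond the scatter, estimated as a 33-fold lower number from compound 3 to compound 4 (1.52 log units; beyond the scatter). Compound 4 is estimated at 3000 nM in this assay, with an expected range from 400 nM to 30000 nM.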

Compound 4, half-maximal inhibitory concentration: 22000 nM
Compound 4: the middle estimate sits 7.3-fold (0.87 log units) below what was measured; the range from low to high includes it.
By their numbers in this assay, from the lowest: compound 4; then compounds 2 and 3 (each within the scatter of the next). At a limit, above all of these: compound 1.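

Going by these compounds alone, the step of a 4.5-fold lower number from compound 3 to compound 4 (0.66 log units; beyond the scatter) is the first single-place change, and it shows that a substituent on this nitrogen on an aromatic ring can move the number in this assay beyond the scatter. Compound 2 and compound 3 lay within the scatter of each other and gave no such reading for any one place, whereas isobutoxycarbonyl in place of hydrogen gives a modest but readable gain. No measurement shown bears on the reason for this step.

Which part of the isobutoxycarbonyl group carries the step stays open: an acetyl group, a longer chain, or a chain ending in an amine or a carboxylic acid on the same nitrogen would separate its parts. Going by these compounds, whether the same change gives a step of like size on another core, such as that of compound 2, also stays open.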